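This account rests on a few compounds, and the source may have more. Where it says the series, first, only, none or still open, it means among the compounds named here.

Compound 1 `C=CCn1c(=O)/c(=C\c2cccc(Cl)c2)[nH]c(=O)/c1=C\c1ccccc1OC` gives 2700 nM in a functional assay on K562 cells (Homo sapiens) for cytotoxicity, read by CCK-8 assay, with a stated time of 72 h; a lower number here means a stronger inhibitor, a higher number a weaker inhibitor.
Compound 2 `C=CCn1c(=O)/c(=C\c2cccc(Cl)c2Cl)[nH]c(=O)/c1=C\c1ccccc1OC` gives 900 nM in this assay.
Compound 3 `C=CCn1c(=O)/c(=C\c2cccc(Br)c2)[nH]c(=O)/c1=C\c1ccccc1OC` gives 2400 nM in this assay.

Compound 3 stands second highest of these three numbers. Its nearest neighbour is compound 1, whose value lies within the scatter of it, while compound 2 sits a modest way below it, as the step of a 2.7-fold higher number from compound 2 to compound 3 (0.43 log units; beyond the scatter) shows. Compound 4 `C=CCn1c(=O)/c(=C\c2ccc(C)cc2)[nH]c(=O)/c1=C\c1ccccc1OC` has not yet been measured; it differs from compound 3 in one place: 4-methylphenyl in place of 3-bromophenyl on a double-bonded chain carbon bound to an aromatic carbon. Among the measured compounds shown here, none of the measured steps makes exactly this change. The closest guidance comes from a 1.1-fold lower number from compound 1 to compound 3 (0.05 log units; within the scatter), where bromo in place of chloro on an aromatic carbon left the number within the scatter, and from a 3.0-fold lower number from compound 1 to compound 2 (0.48 log units; beyond the scatter), where an added chloro brought a modest improvement. For the measured compounds named here, a 4-methylphenyl group carrying no chloro or bromo has no precedent among the measured compounds, so the step of a 1.5-fold higher number from compound 3 to compound 4 (0.16 log units; within the scatter) is expected to be small, possibly within the scatter, and a slightly higher number is thought somewhat more likely than a lower one. Compound 4 is therefore estimated at 3500 nM, with a range from 1500 nM to 8000 nM.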

Compound 4, half-maximal inhibitory concentration: "not active" (no number reported)
No number was reported for compound 4; no gap can be computed for the estimate.
By their numbers in this assay, from the lowest: compound 2; then compounds 3 and 1 (each within the scatter of the next).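

Among the compounds shown here, compound 4 is reported in this assay only as "not active", with no number, so no step between it and compound 3 or any other compound can be read. The compounds shown leave open how far compound 4 lies from compound 3 (2400 nM) and what lies behind the difference. No evidence given here explains this result.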